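A few compounds are considered here, and "the series" means these few. Any claim that something is new, unique, unknown or untested is made for them only; others in the source may bear on it.

In a functional assay on HONE1 cells for cytotoxicity against HONE1 cell line (Homo sapiens) (a higher number here means a weaker inhibitor, a lower number a stronger inhibitor), compound 2 `N#C/N=C1\N(CCCCCOc2ccc(Cl)cc2)C(=O)C(c2ccccc2)N1c1ccncc1` gives 373 nM, the lowest of the two numbers recorded. Going by the values given here, compound 1 `CCC1C(=O)N(CCCCCCCOc2ccc(Cl)cc2)/C(=N\C#N)N1c1ccncc1` in this assay gives 3230 nM; these two structures differ in more than one place, so the pair shows only that compound 1 stands well beyond the scatter from compound 2. Compound 3 `N#C/N=C1\N(CCCCCCCOc2ccc(Cl)cc2)C(=O)C(c2ccccc2)N1c1ccncc1` is not yet measured; it carries 2-(4-chlorophenoxy)ethyl in place of 4-chlorophenoxy on a saturated chain carbon, five bonds along the chain from an amide-type nitrogen in a ring. Among the compounds with values here, no single-change step between measured compounds is available, so the expectation is a modest weakening or none beyond the scatter, the step being estimated at a 1.7-fold higher number from compound 2 to compound 3 (0.24 log units; within the scatter). Compound 3 is expected near 650 nM, within 200 nM to 2500 nM.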

Compound 3, half-maximal inhibitory concentration: 398 nM
The estimate for compound 3 lay 1.6-fold (0.21 log units) above the measured number; measured number inside the range.
By their numbers in this assay, from the lowest: compounds 2 and 3 (each within the scatter of the next); then compound 1.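

In this assay, 2-(4-chlorophenoxy)ethyl in place of 4-chlorophenoxy on a saturated chain carbon gives a 1.1-fold higher number from compound 2 to compound 3 (0.03 log units; within the scatter) and so leaves the number unresolved from that of the shorter chain. With the chain held constant, phenyl in place of ethyl on a saturated ring carbon gives an 8.1-fold lower number from compound 1 to compound 3 (0.91 log units; beyond the scatter) and so marks this ring carbon as a place where the number responds. Nothing available explains either result. Still open, from the compounds shown here alone, is whether a benzyl group on that ring carbon would match phenyl. Also open, going by these compounds, is how an amine or a carboxylic acid in place of the chlorine would read.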